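Epimer step at a ring stereocentre in the diketone series

The compounds below may be only part of what the source reports. "The series", "measured", "known", "first", "only" and "open" are said of these compounds alone.

Of the compounds shown here, two have numbers so far. In a functional assay on the whole organism (liver) for inhibition, with Mus musculus as the target, at a dose of 50 mg/kg by the oral route (on this read-out lower numbers stand for less inhibition and higher numbers for more inhibition at the one dose given (going by the name of the read-out)), compound 1 `C/C1=C\CC[C@]2(C)O[C@H]2C(=O)c2c(C)coc2C1` gives 35.4%. Compound 2 `C/C1=C\CC[C@H](C)C(=O)C[C@@H](C(C)C)C(=O)C1` stands highest of the two in this assay, giving 74.6%, and its gap to compound 1 lies beyond the usual scatter. Compound 3 `C/C1=C\CC[C@@H](C)C(=O)C[C@@H](C(C)C)C(=O)C1` is not yet measured; its change from compound 2 is the two compounds have the same atoms and bonds and differ only in configuration as drawn: 1 of 3 stereo elements differ; a stereocentre at a saturated ring carbon is drawn S in compound 2 and R in compound 3. Going by the values given here, no measured pair shows this kind of change, so the size of the step is unknown; a modest drop in this assay is expected, though a step within the scatter cannot be excluded. Compound 3 is estimated at 62%, in a range from 35% to 85%, an expected step of a number 12.6 percentage points lower from compound 2 to compound 3 (beyond the scatter).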

Compound 3, a percentage reported as inhibition, in the whole organism at one dose (the size of the read-out at that dose, not a potency): 58.4%
Estimate against measurement, compound 3: 3.6 percentage points above; the range from low to high includes it.
By their numbers in this assay, from the lowest: compound 1; then compound 3; then compound 2.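

In this assay the configuration at this saturated ring carbon alone moves the read-out, with a number 16.2 percentage points lower from compound 2 to compound 3 (beyond the scatter). The S form, compound 2, reads higher, while the R form, compound 3, still retains much of the inhibition at the one dose given. The step can be assigned to this single stereocentre because nothing else changes: the fact that compounds 2 and 3 differ only in the configuration as drawn

As far as these compounds go, whether the other stereo elements respond in the same way stays open, as does the size of this step at other doses. Also open, from the compounds shown here alone, is how a carboxylic acid or a longer chain in place of the isopropyl group would affect this read-out.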